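A Swap to 4-Iodophenyl at the Assay Limit

The compounds below may be only part of what the source reports. "The series", "measured", "known", "first", "only" and "open" are said of these compounds alone.

In an ADME assay on MDBK cells (Bos taurus) for cytotoxicity (a higher number here means that more compound is tolerated, a lower number that less compound is tolerated), compound 1 (`Clc1cccc(Cn2ccc3nc(-c4ccccc4)nc-3c2)c1`) gives > 100000 nM, which is a limit of the assay and not a number. Compound 2 (`N#Cc1ccccc1Cn1ccc2nc(-c3ccccc3)nc-2c1`) gives > 100000 nM, which is likewise only a limit. The record so far is therefore (the limit of > 100000 nM in this assay, at which 2 of the 2 values shown sit). Among the compounds with values here, the one measured step is a step that the two limits leave unreadable from compound 1 to compound 2.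

Compound 3 (`Ic1ccc(Cn2ccc3nc(-c4ccccc4)nc-3c2)cc1`) differs from compound 2 by 4-iodophenyl in place of 2-cyanophenyl on a saturated chain carbon bound to an aromatic nitrogen, with 4-iodophenyl in place of 2-cyanophenyl on a saturated chain carbon bound to an aromatic nitrogen. Within the data shown here, with a step that the two limits leave unreadable from compound 1 to compound 2 as the only guide, no step beyond the scatter is expected in this assay, and no direction can be given. The expected change is a number no higher from compound 2 to compound 3 (the limit leaves the size open). For compound 3 the estimated value is 100000 nM, with an expected range of 40000 nM to 200000 nM.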

Compound 3, half-maximal cytotoxic concentration: 22000 nM
Compound 3: the middle estimate sits 4.5-fold (0.66 log units) above what was measured, outside the stated range (below it).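

Compound 3 is the only one of the three to give a reading that is a number in this assay, which shows that the group on a saturated chain carbon bound to an aromatic nitrogen can change the read-out: 4-iodophenyl brings an at least 4.5-fold lower number from compound 2 to compound 3 (0.65 log units; beyond the scatter) and an at least 4.5-fold lower number from compound 1 to compound 3 (0.65 log units; beyond the scatter). Both sizes are minimum sizes, and the step between 3-chlorophenyl and 2-cyanophenyl cannot be read. Compound 3 thus stands apart from the other two compounds, which remain at the limit: the limit of > 100000 nM in this assay, at which 2 of the 3 values shown sit.

The compounds shown leave open whether the step goes with the iodine itself or with the 4 position, which 4-iodophenyl does not share with either group it replaces. They also do not tell how a 4-chlorophenyl group, or an amine or a carboxylic acid on that ring, would read in this assay.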